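A Second Methoxy Group and the Step It May Cost

A few compounds are considered here, and "the series" means these few. Any claim that something is new, unique, unknown or untested is made for them only; others in the source may bear on it.

Measured compounds:
compound 1, `COc1ccc(C2=NN(C(C)=O)C(c3cccc([N+](=O)[O-])c3)O2)cc1`: 47000 nM
compound 2, `COc1ccc(C2=NN(C(C)=O)C(c3ccc(OC)c([N+](=O)[O-])c3)O2)cc1`: > 100000 nM (a limit)
compound 3, `COc1ccc(C2=NN(C(C)=O)C(c3ccccc3OC)O2)cc1`: 5800 nM

In a functional assay on L1210 cells (Mus musculus) for antiproliferative activity, read by MTT assay, with a stated time of 72 h (a higher number here means a weaker inhibitor, a lower number a stronger inhibitor), compound 1 gives 47000 nM. Compound 2 reaches only a limit of this assay, > 100000 nM. Compound 3 gives 5800 nM in this assay, the lowest of the two numbers. How the core of compound 3 differs from that of compound 1 is not broken down here.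

The change from compound 1 to compound 2 is methoxy in place of hydrogen on an aromatic carbon and it brought an at least 2.1-fold higher number from compound 1 to compound 2 (0.32 log units; beyond the scatter). Because of the limit of > 100000 nM in this assay, at which 1 of the 3 values shown sits, that step is known only as a lower bound.

Compound 4, `COc1ccc(C2=NN(C(C)=O)C(c3cc(OC)ccc3OC)O2)cc1`, is not yet measured. It carries the same kind of change, (methoxy in place of hydrogen on an aromatic carbon), but the surroundings differ: in compound 2 the new group sits ortho to a nitro group and para to a large group, in compound 4 meta to a large group and para to a methoxy group. Resting on the earlier step, an at least 2.1-fold higher number from compound 1 to compound 2 (0.32 log units; beyond the scatter), a weakening is expected, a 2.2-fold higher number from compound 3 to compound 4 (0.35 log units; beyond the scatter). Compound 4 is therefore estimated at 13000 nM, expected to fall between 4500 nM and 40000 nM.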

Compound 4, half-maximal inhibitory concentration: 500 nM
Beside the measured number, compound 4's estimate is 26-fold (1.41 log units) above it; measured number outside the range, below it.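

In this assay, within the data shown here, methoxy in place of hydrogen on an aromatic carbon brought a 12-fold lower number from compound 3 to compound 4 (1.06 log units; beyond the scatter), so the change that had weakened compound 2 strengthened compound 4, and the two steps do not agree: the same change on two cores in this assay, an at least 2.1-fold higher number (0.32 log units; beyond the scatter) from compound 1 to compound 2 and a 12-fold lower number (1.06 log units; beyond the scatter) from compound 3 to compound 4, at least 24-fold (1.39 log units) apart, beyond the scatter of two such steps The earlier step is known only as a bound, since compound 2 stands at a limit of the assay: the limit of > 100000 nM in this assay, at which 1 of the 4 values shown sits. This shows that the effect of this change did not carry from one core to the other here, but with only two pairs it gives no rule for the series, and it does not tell which difference between the two surroundings, the nitro group of compound 2 or the methoxy group of compound 4, decides the direction.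

The compounds shown leave open whether a hydroxy group, an ethoxy group or an amine in the place of the new methoxy of compound 4 would keep its lower number. They also leave open whether a chlorine in that place would follow the same direction.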